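Swapping the Aryl Group on the Amide Nitrogen

The source may report more compounds than this note shows. Statements on the series, on what has been measured and on what is new or still open speak of the compounds shown alone.

Of the compounds shown here, three sharing one core have been measured in a functional assay on the whole organism for inhibition, with Rattus norvegicus as the target, read by paw edema, with stated times of 30 min and 2 h, at a dose of 0.28 mmol/kg by the oral route; a higher number here means more inhibition at the dose given (going by the name of the read-out), a lower number less inhibition. Compound 1 `COc1ccc(NC(=O)c2nc(-c3cc(OC)c(OC)c(OC)c3)n(-c3ccc(OC)cc3)n2)cc1` gives 45%, compound 2 `COc1ccc(-n2nc(C(=O)Nc3ccc(C)cc3)nc2-c2cc(OC)c(OC)c(OC)c2)cc1` gives 60%, and compound 3 `COc1ccc(-n2nc(C(=O)Nc3cccc(F)c3)nc2-c2cc(OC)c(OC)c(OC)c2)cc1` gives 67%, the highest of the three numbers; its gap to compound 2 lies within the scatter, while its gap to compound 1 lies beyond it. The step of a number 22 percentage points higher from compound 1 to compound 3 (beyond the scatter) and the step of a number 7 percentage points higher from compound 2 to compound 3 (within the scatter) both exchange the group on the amide-type nitrogen, as does the move to compound 4 `COc1ccc(-n2nc(C(=O)Nc3ccc(C(=O)O)cc3)nc2-c2cc(OC)c(OC)c(OC)c2)cc1`: 4-carboxyphenyl in place of 3-fluorophenyl on an amide-type nitrogen. Going by the values given here, neither measured step involves a carboxyphenyl group, so they show only that exchanging the aryl group at this position has given modest shifts or shifts within the scatter in this assay. Among the compounds with values here, with no precedent for a carboxylic acid here, the writer expects compound 4 to stay near the measured numbers while allowing for a somewhat lower result: a step of a number 12 percentage points lower from compound 3 to compound 4 (beyond the scatter) is expected, giving an estimated 55% with a range from 30% to 75%.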

Compound 4, a percentage reported as inhibition, in the whole organism at one dose (the size of the read-out at that dose, not a potency): 57%
The estimate for compound 4 lay 2 percentage points below the measured number, and the stated range covers the measured number.
By their numbers in this assay, from the lowest: compound 1; then compounds 4, 2 and 3 (each within the scatter of the next).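

With a 4-carboxyphenyl group on the amide-type nitrogen, the reading in this assay shows a number 10 percentage points lower from compound 3 to compound 4 (within the scatter) and also a number 3 percentage points lower from compound 2 to compound 4 (within the scatter) so this position takes an aryl group bearing a carboxy without moving past the scatter from the other two. Going by these compounds alone, the one new step beyond the scatter is a number 12 percentage points higher from compound 1 to compound 4 (beyond the scatter) and with it compound 1 stays set apart, as it already was from compound 2 and compound 3. No supporting measurement is available to explain how the carboxy group produces this result.

The compounds shown leave open how a methyl ester, a primary amide or an amine in place of the carboxy would read at this position. They also leave open whether a longer chain between the aromatic ring and the carboxylic acid would keep the reading in the same range.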